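The compounds below may be only part of what the source reports. "The series", "measured", "known", "first", "only" and "open" are said of these compounds alone.

Measured so far:
Compound 1 `Nc1ncnc2c1c(-c1ccc(Oc3ccccc3)cc1)cn2C[C@H]1CCCN1C[C@@H](O)CO`: 13500 nM
Compound 2 `Nc1ncnc2c1c(-c1ccc(C(=O)Nc3ccc(Oc4ccccc4)cc3)cc1)cn2[C@H]1CCN(C[C@@H]2CO2)C1`: 3630 nM

In a functional assay on Ramos cells (Homo sapiens) for antiproliferative activity (a lower number here means a stronger inhibitor, a higher number a weaker inhibitor), compound 1, at 13500 nM, stands higher of the two, and compound 2, at 3630 nM, lies below it beyond the scatter. Compound 3 `Nc1ncnc2c1c(-c1ccc(Oc3ccccc3)cc1)cn2C[C@H]1CCCN1C(CO)CO` keeps the core of compound 1 but carries 2-hydroxy-1-(hydroxymethyl)ethyl in place of 2,3-dihydroxypropyl on an amine nitrogen in a ring. Going by the values given here, no measured pair shows this change, so no shift beyond the scatter is expected in this assay. The estimated shift is a 1.1-fold lower number from compound 1 to compound 3 (0.05 log units; within the scatter). Compound 3 is expected at 12000 nM, within an estimated range of 4500 nM to 30000 nM.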

Compound 3, half-maximal inhibitory concentration: 15300 nM
Compound 3: middle estimate off by 1.3-fold (0.11 log units), on the low side; measured number inside the range.
By their numbers in this assay, from the lowest: compound 2; then compounds 1 and 3 (each within the scatter of the next).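

In this assay, placing 2-hydroxy-1-(hydroxymethyl)ethyl in place of 2,3-dihydroxypropyl on the amine nitrogen of the five-membered ring gives a 1.1-fold higher number from compound 1 to compound 3 (0.05 log units; within the scatter). At this position, then, rejoining the same atoms into a different side chain, which also removes the defined stereocentre of 2,3-dihydroxypropyl, leaves the two compounds within the scatter of each other. Nothing available explains this result. From the compounds shown here alone, whether an amine, a carboxylic acid or a longer chain on this nitrogen would separate from compound 1 remains open.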